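Replacing the 4-methylpiperazin-1-yl amide of compound 3

The source may report more compounds than this note shows. Statements on the series, on what has been measured and on what is new or still open speak of the compounds shown alone.

In a functional assay on DLD-1 cells (Homo sapiens) for antiproliferative activity, read by sulforhodamine B assay, with a stated time of 48 h (on this read-out lower numbers stand for stronger inhibition and higher numbers for weaker inhibition), compound 3 (`COc1ccc(-c2oc3c(OC)c(OC)cc(OCCCCC(=O)N4CCN(C)CC4)c3c(=O)c2O)cc1`) gives > 40000 nM as a limit of the assay, not a number. Compound 1 (`COc1ccc(-c2oc3c(OC)c(OC)cc(OCCCC(=O)N4CCN(C)CC4)c3c(=O)c2O)cc1`) likewise gives > 40000 nM as a limit. Compound 2 (`CCCCN(C)C(=O)CCCCOc1cc(OC)c(OC)c2oc(-c3ccc(OC)cc3)c(O)c(=O)c12`) gives 17400 nM as a measured number.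

Compound 4 (`CCCCCN(C)C(=O)CCCCCOc1cc(OC)c(OC)c2oc(-c3ccc(OC)cc3)c(O)c(=O)c12`) carries (methyl(pentyl)carbamoyl)methyl in place of (4-methylpiperazin-1-yl)carbonyl on a saturated chain carbon, four bonds along the chain from an oxygen on an aromatic ring.

The nearest measured steps are an at least 2.2-fold higher number from compound 2 to compound 3 (0.36 log units; beyond the scatter) and an at least 2.2-fold lower number from compound 1 to compound 2 (0.36 log units; beyond the scatter), and both leave the butyl(methyl)amino amide, compound 2, with the lower number. A lower number is therefore expected here, of at least modest size. The expected step is an at least 3.3-fold lower number from compound 3 to compound 4 (0.52 log units; beyond the scatter) in this assay overall. For compound 4 the estimate is 12000 nM, with an expected range of 4000 nM to 35000 nM as its span.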

Compound 4, half-maximal inhibitory concentration: 19400 nM
Estimate against measurement, compound 4: 1.6-fold (0.21 log units) below, within the range that was stated.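

In this assay, the open-chain amide with a longer tether again separates from the 4-methylpiperazin-1-yl amides, with an at least 2.0-fold lower number from compound 3 to compound 4 (0.31 log units; beyond the scatter) and an at least 2.0-fold lower number from compound 1 to compound 4 (0.31 log units; beyond the scatter). Both piperazine amides still sit at a limit of the assay: the limit of > 40000 nM in this assay, at which 2 of the 4 values shown sit. Within the open-chain pair, butyl(methyl)carbamoyl gives way to (methyl(pentyl)carbamoyl)methyl with a 1.1-fold higher number from compound 2 to compound 4 (0.05 log units; within the scatter), so this extension brings no readable change.

Going by these compounds, whether the piperazine ring itself or its methylated nitrogen goes with the limit stays open. A morpholine amide, a secondary amide or a free carboxylic acid on the chain could separate these.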